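Adding a second methoxy to a weak prolyl 4-hydroxylase inhibitor

The compounds below may be only part of what the source reports. "The series", "measured", "known", "first", "only" and "open" are said of these compounds alone.

Of the compounds shown here, two sharing one core have been tested in an assay on isolated protein (Gallus gallus) for inhibition of transmembrane prolyl 4-hydroxylase (Homo sapiens); a higher number here means a weaker inhibitor, a lower number a stronger inhibitor. Compound 1 `O=C(Nc1ccccc1F)c1ccc(C(=O)O)nc1` gives 11000 nM. Compound 2 `COc1ccccc1NC(=O)c1ccc(C(=O)O)nc1`, which carries a methoxy in place of the fluoro on an aromatic carbon, gives 14800 nM. The step of a 1.3-fold higher number from compound 1 to compound 2 (0.13 log units; within the scatter) is small, so the two numbers cannot be told apart; compound 2 simply has the higher of the two numbers shown, with compound 1 as its only neighbour.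

Compound 3 `COc1ccc(NC(=O)c2ccc(C(=O)O)nc2)c(OC)c1` differs from compound 2 by methoxy in place of hydrogen on an aromatic carbon. For the measured compounds named here, no measured pair carries this exact change. Going by the values given here, the only step available, a 1.3-fold higher number from compound 1 to compound 2 (0.13 log units; within the scatter), concerns a different swap on the same six-membered aromatic ring of carbon only and stayed within the scatter. Among the compounds with values here, that step is the sole guide and it points to no shift beyond the scatter for this assay, in either direction, though a single step is thin evidence. Compound 3 is therefore expected to give about 15000 nM, within a range of 6000 nM to 40000 nM, corresponding to an estimated step of a 1.0-fold higher number from compound 2 to compound 3 (0.01 log units; within the scatter).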

Compound 3, half-maximal inhibitory concentration: 16600 nM
For compound 3 the middle estimate is 1.1-fold (0.04 log units) below the measured one; low and high end bracket the measured number.
By their numbers in this assay, from the lowest: compounds 1, 2 and 3 (each within the scatter of the next).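

In this assay the new methoxy, placed meta to a methoxy group and para to a large group, gives a 1.1-fold higher number from compound 2 to compound 3 (0.05 log units; within the scatter), so compound 2 and compound 3 cannot be told apart. The earlier step only swapped one group for another on this ring, whereas this one puts a methoxy where a hydrogen stood, showing that this position can carry that extra group with no difference that this measurement can resolve. Nothing available here accounts for this lack of a measurable difference.

As far as these compounds go, one methoxy at one position says little about the position in general, so it remains open whether an amine or a carboxylic acid placed there would give a step beyond the scatter. A longer chain in the same place is just as open, as is whether any group on this ring can move the number clearly away from the level of compound 1 at 11000 nM.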